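A few compounds are considered here, and "the series" means these few. Any claim that something is new, unique, unknown or untested is made for them only; others in the source may bear on it.

Compound 1 `CCCCCCCc1ccc(NS(=O)(=O)c2ccc(N3CCNC3=O)cc2)cc1`: > 1000 nM
Compound 2 `O=C1NCCN1c1ccc(S(=O)(=O)Nc2ccc(Cl)cc2)cc1`: 90 nM

For the measured compounds named here, in a functional assay on M21 cells (Homo sapiens) for antiproliferative activity, read by sulforhodamine B assay, with a stated time of 48 h (on this read-out higher numbers stand for weaker inhibition and lower numbers for stronger inhibition), compound 2 gives 90 nM, the only actual number so far. For compound 1, > 1000 nM is a limit of the assay and not a number. Compound 3 `CCCCCCOc1ccc(NS(=O)(=O)c2ccc(N3CCNC3=O)cc2)cc1` carries hexyloxy in place of chloro on an aromatic carbon, para to a large group: hexyloxy in place of chloro on an aromatic carbon. Going by the values given here, the one measured step that bears on this runs the other way, chloro in place of heptyl, and it was large: an at least 11-fold lower number from compound 1 to compound 2 (1.04 log units; beyond the scatter). Putting a long chain back is therefore expected to give a large rise in the number, with an estimated 8.9-fold higher number from compound 2 to compound 3 (0.95 log units; beyond the scatter). Compound 3 is estimated at 800 nM, with an expected range of 200 nM to 3000 nM.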

Compound 3, half-maximal inhibitory concentration: > 1000 nM
Compound 3: no number, only a limit; the forecaster's own chance of this, stated with the estimate: 45%; middle value at least 1.2-fold (0.09 log units) away from the limit.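

Hexyloxy in place of chloro gives an at least 11-fold higher number from compound 2 to compound 3 (1.04 log units; beyond the scatter) in this assay, so at this position a long chain joined through oxygen loses activity just as the heptyl chain does, and the loss is not confined to a chain of carbon alone. The step from compound 1 to compound 3 cannot be read, because both compounds rest on the same limit: the limit of > 1000 nM in this assay, at which 2 of the 3 values shown sit.

Still open, on these data alone, is how short a chain must be to keep the activity of compound 2, which methoxy or ethyl would test. An amine or a carboxylic acid at this position also remains untested among the compounds shown.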